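Trifluoromethoxy in place of chloro: an expected growth inhibition

This account rests on a few compounds, and the source may have more. Where it says the series, first, only, none or still open, it means among the compounds named here.

In a functional assay on Bel-7402 cells (Homo sapiens) for inhibition, read by MTT assay, with a stated time of 24 h, tested at 100 ug/mL (a lower number here means less inhibition of growth, a higher number more inhibition of growth at the concentration tested), compound 1 `CC(=O)SCCC(CCCCC(=O)O)SC(C)=O` gives 8.35% and compound 2 `O=C(CCCCC(S)CCS)Nc1ccccc1` gives 7.67% while compound 3 `O=C(CCCCC(S)CCS)Nc1ccc(Cl)cc1` reaches 25.5% as the highest of the three numbers. Both other compounds lie lower than compound 3 by gaps beyond the scatter.

The next compound, compound 4 `O=C(CCCCC(S)CCS)Nc1ccc(OC(F)(F)F)cc1` keeps the shared core of compound 3 and carries trifluoromethoxy in place of chloro on an aromatic carbon of a six-membered aromatic ring of carbon only, para to a large group. Among the measured compounds shown here, one measured step bears on this change: the result for chloro in place of hydrogen on an aromatic carbon is a number 17.8 percentage points higher from compound 2 to compound 3 (beyond the scatter) and it is the only measured step at this place. For the measured compounds named here, no measured compound carries trifluoromethoxy, so that modest step also sets the likely scale of any movement. Since the new group also replaces chloro rather than restoring hydrogen, no step beyond the scatter is expected, and a move of that modest size in either direction remains possible. The expected change is a number 0.5 percentage points lower from compound 3 to compound 4 (within the scatter) (an estimate within the scatter). In this assay compound 4 is estimated at 25% with an expected range of 12% to 42% (a rough estimate).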

Compound 4, percent growth inhibition at one concentration: 49.7%
Estimate against measurement, compound 4: 24.7 percentage points below, and the stated range ends below it.
By their numbers in this assay, from the lowest: compounds 2 and 1 (each within the scatter of the next); then compound 3; then compound 4.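

Among the compounds shown here, at this place on the aromatic ring, para to a large group, the earlier compounds showed only that chloro in place of hydrogen gives a number 17.8 percentage points higher from compound 2 to compound 3 (beyond the scatter) in this assay. The new result shows that the number also responds to which group stands there, not only to whether hydrogen has been replaced: trifluoromethoxy in place of chloro gives a number 24.2 percentage points higher from compound 3 to compound 4 (beyond the scatter). Trifluoromethoxy in place of hydrogen gives a number 42 percentage points higher from compound 2 to compound 4 (beyond the scatter), so this is the first change at this place to produce a large step, and both groups shown here raise the number over hydrogen. Nothing available here accounts for this difference between the two groups.

The compounds shown leave open whether a methoxy group, a trifluoromethyl group or an amine at this place would follow chloro, follow trifluoromethoxy or leave the number near that of the hydrogen compound. They also leave open whether trifluoromethoxy would give a similar step on another aromatic carbon of the ring, and how the order of these compounds would look across a range of concentrations rather than at the single one tested.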